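A few compounds are considered here, and "the series" means these few. Any claim that something is new, unique, unknown or untested is made for them only; others in the source may bear on it.

Measured so far in an assay on isolated protein for inhibition of Leucine-rich repeat serine/threonine-protein kinase 2 (Homo sapiens), read by TR-FRET and LanthaScreen, with stated times of 50 min and 30 min, in the presence of a further agent that is not named here; a lower number here means a stronger inhibitor, a higher number a weaker inhibitor:
compound 1 `Cc1c(Nc2nc(N)c3c(C#N)c(N4CCC[C@H]4C)n(C)c3n2)cnn1[C@H]1CCOC1`: 23 nM
compound 2 `Cc1nn(C2CCOC2)cc1Nc1nc(N)c2c(C#N)c(N3CCC[C@H]3C)n(C)c2n1`: 19 nM; 44 nM (2 entries)
compound 3 `C[C@@H]1CCCN1c1c(C#N)c2c(N)nc(Nc3cn(C)nc3Cl)nc2n1C`: 34 nM

Compound 1 carries the lowest of the two single numbers in this assay; its nearest neighbour is compound 3, and that gap is within the scatter, so the two cannot be put in order. Compound 2, which is drawn without a fixed configuration at the oxolane carbon, has been entered more than once, and the several entries of compound 2 in this assay, 19 nM; 44 nM (2 entries) shows its two entries bracketing the number of compound 1 from both sides.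

Compound 4 `Cc1c(Nc2nc(N)c3c(C#N)c(N4CCC[C@H]4C)n(C)c3n2)cnn1[C@@H]1CCOC1` is the next compound to be read in this assay. Relative to compound 1 the change is the two compounds have the same atoms and bonds and differ only in configuration as drawn: 1 of 2 stereo elements differ; a stereocentre at a saturated ring carbon is drawn S in compound 1 and R in compound 4. Among the measured compounds shown here, no measured pair of this kind exists in the set, so the step has to be judged from what compound 2 shows: its spread of entries is consistent with the mirror-image carbon making only a modest difference.

Compound 4 is therefore expected to give 40 nM, in a range of 12 nM to 130 nM. The expected step of a 1.7-fold higher number from compound 1 to compound 4 (0.24 log units; within the scatter) points toward a somewhat weaker number, and may well not exceed the scatter.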

Compound 4, half-maximal inhibitory concentration: 20 nM
Compound 4: the middle estimate sits 2.0-fold (0.30 log units) above what was measured; the measured number falls inside the stated range.
By their numbers in this assay, from the lowest: compounds 4, 1 and 3 (each within the scatter of the next).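

In this assay, inverting the saturated ring carbon gives a 1.2-fold lower number from compound 1 to compound 4 (0.06 log units; within the scatter), so this stereocentre now has a direct reading, and neither configuration can be placed ahead of the other. Compound 2, drawn without a fixed configuration at this carbon, offered only a spread of entries that could not be assigned to either form: the several entries of compound 2 in this assay, 19 nM; 44 nM (2 entries). The new pair leaves no other structural difference, so the reading belongs to this one carbon: the fact that compounds 1 and 4 differ only in the configuration as drawn.

On these data alone, compound 1 and compound 4 share one configuration at the other stereocentre, so it remains open whether the oxolane carbon would matter as little with that centre inverted. Also open, as far as these compounds go, is how an amine or a carboxylic acid on the oxolane would read in this assay, and whether either would make the configuration at this carbon matter.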